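Trimming the Side Chain of a Weakly Cytotoxic Bromo-Naphthyridine

A few compounds are considered here, and "the series" means these few. Any claim that something is new, unique, unknown or untested is made for them only; others in the source may bear on it.

The study measures cytotoxicity in a functional assay on HCT-116 cells (Homo sapiens) for cytotoxicity, read by MTT assay, with a stated time of 72 h; on this read-out lower numbers stand for stronger inhibition and higher numbers for weaker inhibition. Compound 1, with the structure `O=C(NCCCNc1c(C(=O)NCc2ccc(F)cc2)nc(Br)c2cccnc12)c1ccccc1`, gives in this assay only a limit, > 10000 nM, and not a number; this is the boundary at which the read-out stops, as noted in the limit of > 10000 nM in this assay, at which 1 of the 2 values shown sits. Going by the values given here, compound 2, `N[C@H]1CC[C@H](Nc2c(C(=O)NCc3ccccc3)nc(Br)c3cccnc23)CC1`, is the only other measured member and gives in this assay 7000 nM, so the numbers available so far sit at the weak end of the scale.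

Compound 3, `O=C(NCc1ccc(F)cc1)c1nc(Br)c2cccnc2c1NCCO`, has not yet been measured in this assay. It differs from compound 1 in one place: hydroxy in place of benzamidomethyl on a saturated chain carbon, two bonds along the chain from a nitrogen on an aromatic ring. Among the compounds with values here, no measured step between two compounds that differ in a single place is available, so the size of the change cannot be read off from data already in hand.

Given that compound 1 sits at the limit > 10000 nM, the step from compound 1 to compound 3 is expected to be small, a step that the limit leaves unreadable from compound 1 to compound 3, not clearly beyond the scatter in either direction. Compound 3 is therefore estimated to come out near 12000 nM, within a range from 4000 nM to 40000 nM, with a fair chance that this assay again reports only a limit.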

Compound 3, half-maximal inhibitory concentration: > 20000 nM
Compound 3: only a limit was reported; the forecaster's own chance of this, stated with the estimate: 55%; middle value at least 1.6-fold (0.22 log units) from the limit.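

In this assay compound 3 gives > 20000 nM, which is a limit and not a number. Going by these compounds alone, compound 1 likewise gives only a limit, > 10000 nM, so no step from compound 1 to compound 3 can be read. The compounds shown leave open whether hydroxy in place of benzamidomethyl changes the cytotoxicity at all.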